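The source may report more compounds than this note shows. Statements on the series, on what has been measured and on what is new or still open speak of the compounds shown alone.

Measured so far:
compound 1, `O=CCNC(=O)c1cccc(C(F)(F)F)c1`, > 10000 nM 
compound 2, `CC(C=O)NC(=O)c1cccc(C(F)(F)F)c1Cl`, 110 nM 

In an assay on isolated protein for inhibition of cathepsin S (Homo sapiens), read by fluorescence (a lower number here means a stronger inhibitor, a higher number a weaker inhibitor), compound 1 gives only a limit, > 10000 nM, which is the upper limit of the measurement rather than a number. For the measured compounds named here, compound 2 gives the single numeric value in this assay, 110 nM; the other value shown is the limit of > 10000 nM in this assay, at which 1 of the 2 values shown sits, so compound 2 is the only measured compound that can be placed on a scale at all. Going by the values given here, no step between two measured compounds differing in one place is available.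

Compound 3, `CC(NC(=O)c1cccc(C(F)(F)F)c1Cl)C(=O)C(=O)Nc1cc[nH]n1`, has not yet been measured in this assay. It differs from compound 2 by (1H-pyrazol-3-yl)carbamoyl in place of hydrogen on a carbonyl carbon. Among the compounds with values here, no measured step in this assay covers a change of this kind, so the expectation rests on compound 2 alone. Compound 3 is expected to give a lower number than compound 2 in this assay, by a 3.7-fold lower number from compound 2 to compound 3 (0.56 log units; beyond the scatter), a step beyond the usual scatter. For compound 3 the estimate is 30 nM, in the range 5 nM to 200 nM.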

Compound 3, half-maximal inhibitory concentration: 14.1 nM
For compound 3 the middle estimate is 2.1-fold (0.33 log units) above the measured one, within the range that was stated.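

For the compounds shown here, the carbonyl carbon of compound 2, whose other neighbour is a saturated chain carbon, accepts substitution in this assay: (1H-pyrazol-3-yl)carbamoyl in place of hydrogen gives a 7.8-fold lower number from compound 2 to compound 3 (0.89 log units; beyond the scatter) and is the only one-place step so far. Hydrogen on this carbon is therefore not required for inhibition at this level, and a substituent carrying a five-membered aromatic ring is accepted there. Nothing measured in this set accounts for the size of the step.

On these data alone, it remains open whether the gain belongs to the carbamoyl part or to the ring, which a plain primary amide, a carboxylic acid or a phenyl amide at this carbon would separate. As far as these compounds go, compound 1 and compound 2 differ in more than one place, so the separate roles of the chain methyl and the ring chlorine also remain open.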